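The source may report more compounds than this note shows. Statements on the series, on what has been measured and on what is new or still open speak of the compounds shown alone.

Working notes on the series.

Compound 1 `Cn1c(-c2ccccc2F)cnc1NC(=O)c1ccc(F)cc1` is the reference point. In a toxicity assay on THP-1 cells (Homo sapiens) for inhibition (on this read-out higher numbers stand for lower toxicity in this test and lower numbers for higher toxicity in this test), compound 1 gives only a limit, > 100000 nM. Compound 2 `Cn1c(-c2ccccc2[N+](=O)[O-])cnc1NC(=O)c1ccc(F)cc1` carries the change (nitro in place of fluoro on an aromatic carbon). In this assay compound 2 gives 31000 nM. That change made an at least 3.2-fold lower number from compound 1 to compound 2 (0.50 log units; beyond the scatter).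

Compound 3 `COc1ccc(-c2cnc(NC(=O)c3ccc(F)cc3)n2C)cc1` differs from compound 1 by 4-methoxyphenyl in place of 2-fluorophenyl on an aromatic carbon. In this assay compound 3 gives only a limit, >= 50000 nM. The step that the two limits leave unreadable from compound 1 to compound 3 cannot be read because the limit of > 100000 nM in this assay, at which 1 of the 3 values shown sits, and the limit of >= 50000 nM in this assay, at which 1 of the 3 values shown sits, bound both ends of it.

Compound 4 `COc1ccc(-c2cnc(NC(=O)c3ccc([N+](=O)[O-])cc3)n2C)cc1` is not yet measured. It differs from compound 3 by nitro in place of fluoro on an aromatic carbon. Among the measured compounds shown here, this is the same kind of change as the one from compound 1 to compound 2, but not the same: there the entering nitro sits ortho to a large group, here it sits para to a large group.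

The step of an at least 2.0-fold lower number from compound 3 to compound 4 (0.30 log units; that floor lies within the scatter) is expected in this assay, resting on an at least 3.2-fold lower number from compound 1 to compound 2 (0.50 log units; beyond the scatter) and on the fact that compound 3 starts from a limit, >= 50000 nM, so that a number of roughly the size seen for compound 2, 31000 nM, is the nearest guide. For compound 4 in this assay the estimate is 25000 nM, expected to lie between 8000 nM and 80000 nM.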

Compound 4, half-maximal cytotoxic concentration: > 100000 nM
Compound 4: a limit, no number; the forecaster's own chance of this, stated with the estimate: 30%; middle value at least 4.0-fold (0.60 log units) away from the limit.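

In this assay compound 4 gives > 100000 nM as a limit and not a number. No step can be read from compound 3 to compound 4, because both ends are limits: the limit of > 100000 nM in this assay, at which 2 of the 4 values shown sit.
Compound 3 stands at the other limit: the limit of >= 50000 nM in this assay, at which 1 of the 4 values shown sits.
The compounds shown leave open whether nitro in place of fluoro, para to a large group, shifts the number in this assay at all.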